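Compound 3 to compound 4: losing the selenium group

The compounds below may be only part of what the source reports. "The series", "measured", "known", "first", "only" and "open" are said of these compounds alone.

In a functional assay on HCT-116 cells (Homo sapiens) for inhibition, read by MTT assay, with a stated time of 48 h (a lower number here means a stronger inhibitor, a higher number a weaker inhibitor), compound 3 `COc1ccc(N(C)c2nc(C)nc3ccccc23)cc1[Se]C#N` gives 34 nM as the lowest of three measured numbers. Compound 2 `COc1ccc(N(C)c2nc(C)nc3ccccc23)cc1C(=O)NCC[Se]C#N` gives 313 nM in the same test, and compound 1 `COc1ccc(N(C)c2nc(C)nc3ccccc23)cc1OCCCCCC[Se]C#N` gives 6180 nM as the highest.

Compound 4 `COc1ccc(N(C)c2nc(C)nc3ccccc23)cc1OCCN` carries 2-aminoethoxy in place of the selenium-bearing group of compound 3, on an aromatic carbon, ortho to a methoxy group and meta to a large group (a group of 4 heavy atoms (2 carbon, 1 nitrogen, 1 oxygen; no ring) in place of a group of 3 heavy atoms (1 carbon, 1 nitrogen, 1 selenium; no ring), on an aromatic carbon).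

Within the data shown here, three measured steps bear on this change. All concern the size of the selenium-bearing group: a 20-fold lower number from compound 1 to compound 2 (1.30 log units; beyond the scatter) and a 180-fold lower number from compound 1 to compound 3 (2.26 log units; beyond the scatter) are large, and a 9.2-fold lower number from compound 2 to compound 3 (0.96 log units; beyond the scatter) is modest. Among these three compounds, the smaller group goes with the lower number, and none goes against this. However, all three contain selenium, so no measured step shows the effect of removing it. Compound 4 resembles compound 3 in the small size of the group, but shares its oxygen link with compound 1 at 6180 nM as the value.

A modest rise is therefore expected, similar in size to a 9.2-fold lower number from compound 2 to compound 3 (0.96 log units; beyond the scatter), with wide uncertainty. In this assay the estimated change is an 8.8-fold higher number from compound 3 to compound 4 (0.95 log units; beyond the scatter), towards a weaker inhibitor. For compound 4 the estimated value is 300 nM, with a range from 40 nM to 2500 nM expected.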

Compound 4, half-maximal inhibitory concentration: 198 nM
Compound 4: middle estimate off by 1.5-fold (0.18 log units), on the high side, and the stated range covers the measured number.
By their numbers in this assay, from the lowest: compound 3; then compounds 4 and 2 (each within the scatter of the next); then compound 1.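

Working notes on the position ortho to a methoxy group: in this assay, compound 4 is the first compound here without selenium, and a 5.8-fold higher number from compound 3 to compound 4 (0.77 log units; beyond the scatter) prices that exchange for 2-aminoethoxy at this aromatic carbon, while a 1.6-fold lower number from compound 2 to compound 4 (0.20 log units; within the scatter) leaves compound 4 level with the amide-linked selenium compound. Selenium at this position is therefore not needed for a number at the level of compound 2, although the directly attached selenium group of compound 3 remains ahead of both. The oxygen link alone also does not set the high number of compound 1, since changing only the end of the chain gives a 31-fold lower number from compound 1 to compound 4 (1.49 log units; beyond the scatter), so the chain beyond the oxygen matters more than the link itself in this pair. Nothing available gives a reason for any of these steps.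

Open, on these data alone, is whether a selenium-bearing group on an oxygen link of the same length as 2-aminoethoxy would separate the effect of selenium from that of the link. Also open, as far as these compounds go, is how the number responds when the amine is replaced by a carboxylic acid or placed on a longer chain.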